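Chloro to azido on the acetamide arm in two cores

This account rests on a few compounds, and the source may have more. Where it says the series, first, only, none or still open, it means among the compounds named here.

Two cores are compared in a functional assay on KYSE-450 cells (Homo sapiens) for inhibition, read by MTT assay, with a stated time of 48 h; on this read-out higher numbers stand for weaker inhibition and lower numbers for stronger inhibition. Compound 1 `COc1ccc(N(Cc2cc(OC)c(OC)c(OC)c2)C(=O)CCl)cc1O` and compound 2 `COc1ccc(CN(C(=O)CCl)c2cc(OC)c(OC)c(OC)c2)cc1O` are built from the same atoms joined differently; the difference between the two cores is not broken down here. In this assay compound 1 gives 29800 nM, whereas compound 2 gives 210 nM, so the core of compound 2 stands far lower on this read-out, beyond the scatter.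

Compound 3 `COc1ccc(CN(C(=O)CN=[N+]=[N-])c2cc(OC)c(OC)c(OC)c2)cc1O` carries the change azido in place of chloro on a saturated chain carbon bound to a carbonyl carbon on the core of compound 2. In this assay compound 3 gives 160 nM; the step of a 1.3-fold lower number from compound 2 to compound 3 (0.12 log units; within the scatter) lies within the scatter, so no order can be read between compound 2 and compound 3.

Compound 4 `COc1ccc(N(Cc2cc(OC)c(OC)c(OC)c2)C(=O)CN=[N+]=[N-])cc1O` is not yet measured and carries the change azido in place of chloro on a saturated chain carbon bound to a carbonyl carbon on the core of compound 1. The place of the change is worded identically in both pairs, so this is the same change seen in compound 2 to compound 3, now on the other core.

For compound 4 the step of a 1.3-fold lower number from compound 1 to compound 4 (0.11 log units; within the scatter) is expected to be small, resting on the step of a 1.3-fold lower number from compound 2 to compound 3 (0.12 log units; within the scatter), because that step was within the scatter; nothing in the set suggests the change behaves differently on the core of compound 1. Compound 4 is therefore estimated at 23000 nM in this assay, with a range from 9000 nM to 60000 nM.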

Compound 4, half-maximal inhibitory concentration: 26100 nM
Compound 4: the middle estimate sits 1.1-fold (0.05 log units) below what was measured; measured number inside the range.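

In this assay, azido in place of chloro on a saturated chain carbon bound to a carbonyl carbon gives a 1.1-fold lower number from compound 1 to compound 4 (0.06 log units; within the scatter), so no order can be read on the core of compound 1. Set beside the earlier pair, the change carries from one core to the other with no difference that can be read: the same change on two cores in this assay, a 1.3-fold lower number (0.12 log units; within the scatter) from compound 2 to compound 3 and a 1.1-fold lower number (0.06 log units; within the scatter) from compound 1 to compound 4, 1.1-fold (0.06 log units) apart, within the scatter of two such steps This shows agreement only between two steps that are each within the scatter, on two cores and in this single cell assay; it does not show that the change would stay as small on any further core, or that a step beyond the scatter would carry over in the same way.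

Chloro and azido are the only two groups shown on this arm, so it remains open whether an amine, a hydroxyl, a carboxylic acid or a longer chain in the same place would give a number within the scatter of these, or a step beyond it, on either core. From the compounds shown here alone, it also remains open whether a plain acetyl arm, with hydrogen in place of chloro or azido, would keep the number of compound 2 on the core of that compound.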